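Compound 2 to compound 4: a trimethoxyphenyl exchange

This account rests on a few compounds, and the source may have more. Where it says the series, first, only, none or still open, it means among the compounds named here.

In a functional assay on HepG2 cells (Homo sapiens) for cytotoxicity, read by MTT assay, with a stated time of 24 h (a higher number here means a weaker inhibitor, a lower number a stronger inhibitor), compound 2 `O=C1/C(=C/c2cccc([N+](=O)[O-])c2)CN(S(=O)(=O)c2ccc(F)cc2)C/C1=C\c1ccccc1F` gives 7040 nM, within the scatter of both compound 1 `COc1cc(/C=C2\CN(S(=O)(=O)c3ccc(F)cc3)C/C(=C\c3cc(OC)c(OC)c(OC)c3)C2=O)cc(OC)c1OC` at 4200 nM and compound 3 `N#Cc1ccc(/C=C2\CN(S(=O)(=O)c3ccc(F)cc3)C/C(=C\c3ccccc3F)C2=O)cc1` at 8180 nM. Compound 4 `COc1cc(/C=C2\CN(S(=O)(=O)c3ccc(F)cc3)C/C(=C\c3cccc([N+](=O)[O-])c3)C2=O)cc(OC)c1OC` carries 3,4,5-trimethoxyphenyl in place of 2-fluorophenyl on a double-bonded chain carbon bound to a double-bonded ring carbon. For the measured compounds named here, no measured step makes this exchange. Going by the values given here, the only step available, a 1.2-fold higher number from compound 2 to compound 3 (0.07 log units; within the scatter), replaces 3-nitrophenyl and stays within the scatter. Compound 1 also carries 3,4,5-trimethoxyphenyl and lies within the scatter of compound 2. No change beyond the scatter is therefore expected in this assay, and the estimated step is a 1.3-fold lower number from compound 2 to compound 4 (0.11 log units; within the scatter). For compound 4 the expected value is 5500 nM, with an estimated range of 2800 nM to 10800 nM.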

Compound 4, half-maximal inhibitory concentration: 3250 nM
The estimate for compound 4 lay 1.7-fold (0.23 log units) above the measured number; low and high end bracket the measured number.
By their numbers in this assay, from the lowest: compounds 4, 1, 2 and 3 (each within the scatter of the next, the first and the last beyond it).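

In this assay, for the compounds shown here, this position gives the first step beyond the scatter: 3,4,5-trimethoxyphenyl in place of 2-fluorophenyl gives a 2.2-fold lower number from compound 2 to compound 4 (0.34 log units; beyond the scatter) as a modest change. By contrast, 3-nitrophenyl in place of 3,4,5-trimethoxyphenyl gives a 1.3-fold lower number from compound 1 to compound 4 (0.11 log units; within the scatter) at this same kind of place. No measured evidence bears on the cause of either step. Open, as far as these compounds go, is whether an amine or a carboxylic acid at this position would move the number, and whether the 2-fluorophenyl exchange gives a similar step with 4-cyanophenyl on the other side.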